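The source may report more compounds than this note shows. Statements on the series, on what has been measured and on what is new or still open speak of the compounds shown alone.

Among the measured compounds shown here, compound 1, with the structure `Clc1ccc(OCc2nc3c(OCCC4CCNCC4)cccc3n2CCCC2CCCNC2)cc1`, is the stronger of the two compounds measured so far. In an assay on isolated protein for binding affinity to Neuropeptide Y receptor type 1 (Homo sapiens) (on this read-out lower numbers stand for stronger inhibition and higher numbers for weaker inhibition), compound 1 gives 7 nM. For the measured compounds named here, the only other measured compound, compound 2 with the structure `Clc1ccc(OCc2nc3ccccc3n2CCCC2CCCCN2)cc1`, gives 3230 nM in this assay, a far higher number, well beyond the usual scatter; the two structures differ in several places at once, so no single change can be read from that gap.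

Compound 3, with the structure `Clc1ccc(OCc2nc3c(OCCCC4CCNCC4)cccc3n2CCCC2CCCNC2)cc1`, has not yet been measured. It differs from compound 1 in one place: (piperidin-4-yl)methyl in place of piperidin-4-yl on a saturated chain carbon, two bonds along the chain from an oxygen on an aromatic ring. Going by the values given here, no pair of measured compounds shows what this kind of change does in this assay, so there is no direct precedent for its size or direction.

Because compound 1 already gives 7 nM, and the change is a lengthening of one saturated chain by a single link, the step from compound 1 to compound 3 is expected to be small, a 1.7-fold higher number from compound 1 to compound 3 (0.23 log units; within the scatter), most likely within the scatter or only slightly beyond it. The value of compound 3 in this assay is estimated at 12 nM, with a range from 3 nM to 50 nM.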

Compound 3, inhibition constant: 152 nM
For compound 3 the middle estimate is 13-fold (1.10 log units) below the measured one; measured number above the stated range.
By their numbers in this assay, from the lowest: compound 1; then compound 3; then compound 2.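

In this assay, among the compounds shown here, the one structural change in this pair gives a 22-fold higher number from compound 1 to compound 3 (1.34 log units; beyond the scatter) in a single move. Unlike the gap to compound 2, where several places differ at once, this step comes from one change: the ring at the chain end stays the same, and 2-(piperidin-4-yl)ethoxy simply becomes 3-(piperidin-4-yl)propoxy, so in this pair the length of this chain clearly matters. No other measurement here helps explain why the step is so large.

The compounds shown leave open whether a shorter chain, (piperidin-4-yl)methoxy, would give a lower or a higher number than compound 1, so it remains unclear whether the 2-(piperidin-4-yl)ethoxy chain has the best length or merely lies on one side of it. They also leave open whether the piperidine ring is needed at all, or whether a simple amine such as dimethylamino at the end of the same chain would serve as well.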